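The source may report more compounds than this note shows. Statements on the series, on what has been measured and on what is new or still open speak of the compounds shown alone.

Measured so far:
- compound 1, `Nc1n[nH]c2cc(-c3cccnc3)[nH]c(=O)c12`: 26%
- compound 2, `CC(C)(C)c1cc2nn(-c3ccccc3)c(N)c2c(=O)[nH]1`: 15%

In an assay on isolated protein for inhibition of serine/threonine-protein kinase D2 (Homo sapiens), read by mobility shift assay, tested at 30 uM (on this read-out lower numbers stand for less inhibition and higher numbers for more inhibition at the one concentration tested (going by the name of the read-out)), compound 1 gives 26% and compound 2 gives 15%. Compound 2 stands lowest of the two numbers; its nearest neighbour is compound 1, a number higher by a margin beyond the scatter. Among the compounds with values here, compounds 1 and 2 differ in more than one place, so no single step between them can be read off; their two values show only that compound 1 sits higher.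

Compound 3, `COc1ccccc1-c1cc2nn(-c3ccccc3)c(N)c2c(=O)[nH]1`, is not yet measured in this assay. Relative to compound 2 the change is 2-methoxyphenyl in place of tert-butyl on an aromatic carbon.

Within the data shown here, no step within the measured set matches this change, so there is no direct precedent for its size. Only two measured points exist, both at a modest level, and nothing among them shows a large step in either direction. In this assay the step is expected to be small and, if anything, upward: the estimate for compound 3 means a step of a number 7 percentage points higher from compound 2 to compound 3 (within the scatter), which is expected to stay near the scatter. Compound 3 is therefore estimated at 22%, in a range from 5% to 45%.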

Compound 3, a percentage reported as inhibition, at one concentration (the size of the read-out at that concentration, not a potency): 20%
The estimate for compound 3 lay 2 percentage points above the measured number; low and high end bracket the measured number.
By their numbers in this assay, from the lowest: compounds 2, 3 and 1 (each within the scatter of the next, the first and the last beyond it).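

In this assay, within the data shown here, 2-methoxyphenyl in place of tert-butyl on the aromatic carbon next to the ring nitrogen gives a number 5 percentage points higher from compound 2 to compound 3 (within the scatter), the first step that can be read at a single place. This position therefore takes a six-membered aromatic ring carrying a hydrogen-bond acceptor, with 8 heavy atoms in place of 4, and the read-out stays within the scatter, so on this one step compound 2 and compound 3 read alike and neither group stands out from the other. No available data bear on why this exchange leaves the read-out so little altered.

Steps from compound 1 to either of the others cannot be read, since it differs from them in more than one place, so what sets its value apart remains unassigned. Also open, on these data alone, is whether this carbon stays as flat with a plain phenyl lacking the methoxy group, or with a quite different substituent such as an amine or a carboxylic acid, and one step between two groups without charge cannot settle that.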